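The source may report more compounds than this note shows. Statements on the series, on what has been measured and on what is new or still open speak of the compounds shown alone.

Measured so far:

compound 1, `O=C1NC(=O)C(c2ccccc2)CC1c1ccccc1`: in a functional assay on the whole organism (strain Swiss albino) for inhibition, with Mus musculus as the target, in the maximal electroshock model, with a stated time of 2 h, at a dose of 25 mg/kg by the intraperitoneal route (a higher number here means more inhibition at the dose given (going by the name of the read-out), a lower number less inhibition), compound 1 gives 70.2%.
compound 2, `NN1C(=O)C(c2ccccc2)CC(c2ccccc2)C1=O`: in this assay compound 2 gives 76%.

Among the compounds with values here, compound 2 stands alongside compound 1 on these two numbers; the single measured step, a number 5.8 percentage points higher from compound 1 to compound 2 (within the scatter), does not separate them, and no ordering can be claimed.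

Next is compound 3, `Cc1ccc(N2C(=O)C(c3ccccc3)CC(c3ccccc3)C2=O)cc1`, not yet measured in this assay. Its difference from compound 2, computed from the two structures: 4-methylphenyl in place of amino on an amide-type nitrogen in a ring.

Within the data shown here, no measured step bears on this change. Among the measured compounds shown here, the only step known, a number 5.8 percentage points higher from compound 1 to compound 2 (within the scatter), concerns a different substituent on the same amide-type nitrogen in a ring and was within the scatter, so the series gives no direction for an aryl group there. The expectation is therefore anchored to compound 2 with a wide range: the step from compound 2 to compound 3 is estimated as a number 8 percentage points lower from compound 2 to compound 3 (within the scatter), not beyond the scatter in either direction. Compound 3 is expected to give 68%, within 40% to 92%.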

Compound 3, a percentage reported as inhibition, in the whole organism at one dose (the size of the read-out at that dose, not a potency): 43.3%
Compound 3: the middle estimate sits 24.7 percentage points above what was measured; measured number inside the range.
By their numbers in this assay, from the lowest: compound 3; then compounds 1 and 2 (each within the scatter of the next).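

On the amide-type nitrogen in a ring, substitution now moves the read-out in this assay: 4-methylphenyl in place of amino gives a number 32.7 percentage points lower from compound 2 to compound 3 (beyond the scatter) and 4-methylphenyl in place of hydrogen gives a number 26.9 percentage points lower from compound 1 to compound 3 (beyond the scatter) on the same core. Amino and hydrogen at this position could not be told apart, so 4-methylphenyl is the first group in the series to carry the number beyond the scatter, and it does so against both of them. Nothing available here accounts for this fall.

Going by these compounds, whether the fall belongs to the aromatic ring as such or to its methyl group stays open; a plain phenyl or a simple methyl on the same nitrogen would separate the two. On these data alone, how far a larger group can go at this position before the number falls also stays open, as a benzyl or a longer alkyl chain there would show.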